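Hydroxymethyl to methylcarbamoyl at the low end of solubility

The source may report more compounds than this note shows. Statements on the series, on what has been measured and on what is new or still open speak of the compounds shown alone.

Measured so far in a physicochemical assay for solubility, read by LC-MS, in phosphate buffer, with a stated time of 24 h, at pH 7.4; a lower number here means a less soluble compound, a higher number a more soluble compound:
compound 1 `Cc1nc(CO)ccc1-c1cnc(NCc2c(F)ccc3c2CCO3)c2cn[nH]c(=O)c12`: 3000 nM
compound 2 `Cc1ncccc1-c1cnc(NCc2c(F)ccc3c2CCO3)c2n[nH]c(=O)n12`: a limit, < 2000 nM
compound 3 `COCCC(=O)Nc1cnc(NCc2c(F)ccc3c2CCO3)n2cnnc12`: 980000 nM

Of the two numbers reported in this assay, compound 1 has the lower one. The nearest number belongs to compound 3, whose solubility lies far above that of compound 1, a gap well beyond the scatter. For compound 2 the assay returns no number at all but only (the limit of < 2000 nM in this assay, at which 1 of the 3 values shown sits), so compound 2 cannot be placed relative to the other two.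

The piece follows one step from compound 1. Compound 4 `CNC(=O)c1ccc(-c2cnc(NCc3c(F)ccc4c3CCO4)c3cn[nH]c(=O)c23)c(C)n1` has not yet been measured in this assay. It differs from compound 1 in a single place: methylcarbamoyl in place of hydroxymethyl on an aromatic carbon. The leaving group and the entering group each carry one hydrogen-bond donor and one hydrogen-bond acceptor, as counted above, and the entering group is larger by two heavy atoms with one double bond outside aromatic rings.

Going by the values given here, no measured pair in this set shows the same change, so the expectation rests on compound 1 alone. The step of a 1.2-fold lower number from compound 1 to compound 4 (0.08 log units; within the scatter) is expected to be small, leaning slightly lower but not clearly beyond the scatter. Since compound 1 already sits near (the limit of < 2000 nM in this assay, at which 1 of the 3 values shown sits), a reading at the limit for compound 4 would not be surprising. Compound 4 is therefore estimated at 2500 nM in this assay, with a range from 800 nM to 9000 nM.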

Compound 4, solubility: 19000 nM
Compound 4: middle estimate off by 7.6-fold (0.88 log units), on the low side; measured number outside the range, above it.
By their numbers in this assay, from the lowest: compound 1; then compound 4; then compound 3. At a limit, below all of these: compound 2.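

Going by these compounds alone, at this aromatic carbon, next to the ring nitrogen, the change from hydroxymethyl to methylcarbamoyl gives a 6.3-fold higher number from compound 1 to compound 4 (0.80 log units; beyond the scatter) in this assay, the first step between two measured compounds that differ in one place. This shows that a change at this one carbon, with the rest of the structure held constant, can move the reading beyond the scatter, even though the step itself is modest. The hydrogen-bond donor and acceptor counts are the same in the leaving and entering groups, so the rise comes without a change in those counts, while the entering group is the larger one and brings a double bond outside aromatic rings, and nothing measured here accounts for the rise.

With a single step at a single position, the compounds shown do not separate the part played by the methyl on the amide nitrogen from that of the carbonyl, and they do not say whether the same change would give a similar step on another core. A carboxylic acid, an aminomethyl group or an unsubstituted carboxamide at this carbon would each test how far the rise depends on the methylcarbamoyl group itself.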